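The source may hold more compounds than are shown below. What is called first, only, known or untested is meant among the compounds shown, and "the series" means these compounds.

The measured compounds:
Compound 1, `CC1(C)[C@H](c2c[nH]cn2)[C@H]1c1cccc2c1CCO2`, gives > 30000 nM in a functional assay on AP1 cells for inhibition of sodium/hydrogen exchanger 1 (Homo sapiens) (on this read-out higher numbers stand for weaker inhibition and lower numbers for stronger inhibition), which is a limit of the assay and not a number.
Compound 2, `CC1(C)[C@H](c2cnc(N)s2)[C@H]1c1cccc2c1CCO2`, gives > 30000 nM in this assay, again a limit of the assay.
Compound 3, `Cc1[nH]cnc1[C@@H]1[C@@H](c2cccc3c2CCO3)C1(C)C`, gives 11000 nM in this assay.

Among the compounds with values here, compound 3 thus holds the only number among the three in this assay; the two other values are limits. The step of an at least 2.7-fold lower number from compound 2 to compound 3 (0.43 log units; beyond the scatter) and the step of an at least 2.7-fold lower number from compound 1 to compound 3 (0.43 log units; beyond the scatter) are each at least modest and each ends at compound 3 as the lower number, whereas the step that the two limits leave unreadable from compound 1 to compound 2 cannot be read because both of its ends sit at the limit of > 30000 nM in this assay, at which 2 of the 3 values shown sit.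

Compound 4, `CC1(C)[C@H](c2nc(N)no2)[C@H]1c1cccc2c1CCO2`, differs from compound 3 by 3-amino-1,2,4-oxadiazol-5-yl in place of 5-methyl-1H-imidazol-4-yl on a saturated ring carbon. The measured step most like this one is an at least 2.7-fold lower number from compound 2 to compound 3 (0.43 log units; beyond the scatter), a heteroaryl swap at the same saturated ring carbon; read in the opposite direction, moving away from the 5-methyl-1H-imidazol-4-yl left compound 2 at a limit, and compound 1, with yet another heteroaryl there, also at a limit. The writer therefore expects compound 4 to give an at least modest rise in the number, a 2.7-fold higher number from compound 3 to compound 4 (0.44 log units; beyond the scatter), and quite possibly only a limit. The estimate for compound 4 is 30000 nM, with a range from 8000 nM to 100000 nM.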

Compound 4, half-maximal inhibitory concentration: 30000 nM
Estimate against measurement, compound 4: no gap at the digits printed; low and high end bracket the measured number.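

Within the data shown here, with compound 4, a change at this saturated ring carbon can be sized at both ends for the first time, and it is a modest step: a 2.7-fold higher number from compound 3 to compound 4 (0.44 log units; beyond the scatter). The 3-amino-1,2,4-oxadiazol-5-yl, with one more ring hetero atom than the 5-methyl-1H-imidazol-4-yl it replaces, thus costs only a modest rise in the number, and in this assay compound 4 gives a measured 30000 nM, so this carbon now carries a second heteroaryl group with a readable value, although the 5-methyl-1H-imidazol-4-yl of compound 3 keeps the lower number. The two other new steps are a number no higher from compound 2 to compound 4 (the limit leaves the size open) and a number no higher from compound 1 to compound 4 (the limit leaves the size open); their size stays open, and so the new group cannot be ranked against either of their groups, because each of compound 1 and compound 2 sits at a limit of the assay: the limit of > 30000 nM in this assay, at which 2 of the 4 values shown sit.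

The compounds shown leave open whether the methyl of compound 3 is the best group on the imidazole, since an ethyl or a longer chain there has no value among them. They also leave open what a carboxylic acid or a simple amine on this saturated ring carbon would give in this assay.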